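Compound 2 and a methoxymethoxy swap at the carbonyl

A few compounds are considered here, and "the series" means these few. Any claim that something is new, unique, unknown or untested is made for them only; others in the source may bear on it.

Compound 1 `CNC(=O)c1ccccc1SC/C=C(\C)CC/C=C(\C)CCC=C(C)C` gives 10000 nM
Compound 2 `CC(C)=CCC/C(C)=C/CC/C(C)=C/CSc1ccccc1C(N)=O` gives 20000 nM

Going by the values given here, both values come from a functional assay on PANC-1 cells (Homo sapiens) for cytotoxicity, with a stated time of 7 days (a higher number here means a weaker inhibitor, a lower number a stronger inhibitor), where the only measured comparison is a 2.0-fold higher number from compound 1 to compound 2 (0.30 log units; within the scatter). Compound 2 therefore stands level with compound 1 within the scatter. Compound 3 `COCOC(=O)c1ccccc1SC/C=C(\C)CC/C=C(\C)CCC=C(C)C` has not yet been measured. It differs from compound 2 at one place: methoxymethoxy in place of amino on a carbonyl carbon, which puts methoxymethoxy in place of amino on a carbonyl carbon. Among the compounds with values here, the one measured step bears on this only loosely, since it concerns hydrogen in place of methyl on an amide-type nitrogen, whereas here that nitrogen itself leaves. Within the data shown here, no measured step covers the entering group, so the data give no direction. No shift beyond the scatter is expected, and the estimated change is no change at the digits printed from compound 2 to compound 3 (within the scatter), held loosely. For compound 3 the estimated value is 20000 nM, with an expected range from 6000 nM to 60000 nM at the upper end.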

Compound 3, half-maximal inhibitory concentration: 12000 nM
The estimate for compound 3 lay 1.7-fold (0.22 log units) above the measured number, within the range that was stated.
By their numbers in this assay, from the lowest: compounds 1, 3 and 2 (each within the scatter of the next).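

In this assay, the earlier pair had varied only what sits on the amide-type nitrogen, whereas compound 3 removes that nitrogen from the carbonyl carbon altogether and so loses the hydrogen-bond donor of the amino group (a 1.7-fold lower number from compound 2 to compound 3 (0.22 log units; within the scatter)). The same holds against the methylamino group of compound 1 (a 1.2-fold higher number from compound 1 to compound 3 (0.08 log units; within the scatter)), so all three groups on this carbonyl carbon, including the larger methoxymethoxy, lie within the scatter of one another. Nothing measured on these compounds explains this result.

The three compounds leave open whether any group at this carbonyl carbon can move the number beyond the scatter. A carboxylic acid, a simple methyl ester or a dimethylamino group in this place would test that.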